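Benzyl versus pyridylmethyl on the tetrafluorophenylsulfonamide

The compounds below may be only part of what the source reports. "The series", "measured", "known", "first", "only" and "open" are said of these compounds alone.

Measured so far in an assay on isolated protein for inhibition of histone deacetylase 8 (Homo sapiens), read by mobility shift assay; on this read-out higher numbers stand for weaker inhibition and lower numbers for stronger inhibition:
- compound 1, `O=C(NO)c1ccc(CN(Cc2ccccc2)S(=O)(=O)c2c(F)c(F)c(F)c(F)c2F)cc1`: 150 nM
- compound 2, `O=C(NO)c1ccc(CN(Cc2ccncc2)S(=O)(=O)c2c(F)c(F)c(F)c(F)c2F)cc1`: reported as a limit
- compound 3, `O=C(NO)c1ccc(CN(Cc2ccncc2)S(=O)(=O)c2cc(F)c(F)c(F)c2F)cc1`: 581 nM

The value of compound 2, > 1000 nM, is a limit of this assay, not a number (the limit of > 1000 nM in this assay, at which 1 of the 3 values shown sits). Of the two numbers, compound 3 holds the higher one; the nearest number is that of compound 1, which gives 150 nM in this assay. Compound 4, `O=C(NO)c1ccc(CN(Cc2ccccc2)S(=O)(=O)c2cc(F)c(F)c(F)c2F)cc1`, is still to be measured. Its change from compound 3 is phenyl in place of pyridin-4-yl on a saturated chain carbon bound to a sulfonamide nitrogen, which is the reverse of the change from compound 1 to compound 2.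

Among the compounds with values here, two measured steps bear on it. The step of an at least 6.6-fold higher number from compound 1 to compound 2 (0.82 log units; beyond the scatter) shows that pyridin-4-yl in place of phenyl at this position raised the number, the size known only as a floor. The step of an at least 1.7-fold lower number from compound 2 to compound 3 (0.23 log units; that floor lies within the scatter) is small and its floor lies within the scatter, so the fluoro-to-hydrogen context does little to the picture. Going back from pyridin-4-yl to phenyl on compound 3 is therefore expected to lower the number in this assay, and the expected step is a 5.8-fold lower number from compound 3 to compound 4 (0.76 log units; beyond the scatter), a clear gain in inhibition. The value of compound 4 is estimated at 100 nM, with a range from 40 nM to 260 nM.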

Compound 4, half-maximal inhibitory concentration: 155 nM
Estimate against measurement, compound 4: 1.6-fold (0.19 log units) below, within the range that was stated.
By their numbers in this assay, from the lowest: compounds 1 and 4 (each within the scatter of the next); then compound 3. At a limit, above all of these: compound 2.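

In this assay, the change between pyridin-4-yl and phenyl on a saturated chain carbon bound to a sulfonamide nitrogen now has a measured size, a 3.7-fold lower number from compound 3 to compound 4 (0.57 log units; beyond the scatter), where the earlier pair gave only a floor. Its direction is the same on both cores, and neither compound pair goes against it: the same change on two cores in this assay, an at least 6.6-fold higher number (0.82 log units; beyond the scatter) from compound 1 to compound 2 and a 3.7-fold higher number (0.57 log units; beyond the scatter) from compound 4 to compound 3; the limit leaves it open whether they differ With phenyl in place, the change to hydrogen from fluoro on an aromatic carbon, a 1.0-fold higher number from compound 1 to compound 4 (0.01 log units; within the scatter), leaves the two values within the scatter, whereas the pyridin-4-yl pair gives only a floor that also lies within the scatter: the same change on two cores in this assay, an at least 1.7-fold lower number (0.23 log units; that floor lies within the scatter) from compound 2 to compound 3 and a 1.0-fold higher number (0.01 log units; within the scatter) from compound 1 to compound 4; the limit leaves it open whether they differ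

The value of compound 2, > 1000 nM, is a limit and not a number, so the size of the change on the core of compound 1 stays open: the limit of > 1000 nM in this assay, at which 1 of the 4 values shown sits. Also open is how an amine, a carboxylic acid or a longer chain would read at this same place in this assay, since the compounds shown compare only phenyl and pyridin-4-yl there.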